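A few compounds are considered here, and "the series" means these few. Any claim that something is new, unique, unknown or untested is made for them only; others in the source may bear on it.

Compound 3 `CC1CCN(c2c(S(=O)(=O)c3ccc(Cl)cc3)cnc3cc(F)ccc23)CC1` gives 90% in an assay on isolated protein for displacement of a labelled ligand from metabotropic glutamate receptor 5 (Homo sapiens), with a stated time of 60 min, tested at 1 uM (on this read-out higher numbers stand for more inhibition at the one concentration tested (going by the name of the read-out) and lower numbers for less inhibition), which places it level with compound 2 `COc1ccc(S(=O)(=O)c2cnc3cc(F)ccc3c2N2CCC(C)CC2)cc1` at 90% and together with it at the lower end of the three numbers, since no change at the digits printed from compound 2 to compound 3 (within the scatter). The highest number belongs to compound 1 `CC1CCN(c2c(S(=O)(=O)c3ccc(Cl)c(Cl)c3)cnc3cc(F)ccc23)CC1`, which gives 94% in this assay, yet even here a number 4 percentage points lower from compound 1 to compound 3 (within the scatter) and a number 4 percentage points lower from compound 1 to compound 2 (within the scatter). Compound 4 `Cc1ccc(S(=O)(=O)c2cnc3cc(F)ccc3c2N2CCC(C)CC2)cc1F` arises through (3-fluoro-4-methylphenyl in place of 4-chlorophenyl on a sulfonyl sulfur). All three measured steps change the aryl group on that same sulfonyl sulfur, and none of them reaches beyond the scatter, so a further exchange at this position is expected to leave this assay essentially unchanged: a number 2 percentage points lower from compound 3 to compound 4 (within the scatter). Compound 4 is therefore estimated at 88%, with a range from 75% to 97%.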

Compound 4, a percentage reported as inhibition, at one concentration (the size of the read-out at that concentration, not a potency): 89%
For compound 4 the middle estimate is 1 percentage points below the measured one; the measured number falls inside the stated range.
By their numbers in this assay, from the lowest: compounds 4, 2, 3 and 1 (each within the scatter of the next).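

With 3-fluoro-4-methylphenyl on the sulfonyl sulfur, this assay shows a number 1 percentage points lower from compound 3 to compound 4 (within the scatter), a number 1 percentage points lower from compound 2 to compound 4 (within the scatter) and a number 5 percentage points lower from compound 1 to compound 4 (within the scatter). An aryl group carrying both methyl and fluoro thus stays within the scatter of the chloro, dichloro and methoxy aryl groups, so these four compounds do not separate at this position. Nothing measured here bears on why this is so.

On these data alone, whether an aryl group carrying a carboxylic acid or an amine would separate from these numbers stays open. As far as these compounds go, all four numbers come from one concentration, so any differences in potency also remain open.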